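The compounds below may be only part of what the source reports. "The series", "measured", "known", "first", "only" and "open" are said of these compounds alone.

Measured so far in a functional assay on MDA-MB-435 cells (Homo sapiens) for cytotoxicity, read by MTT assay, with a stated time of 72 h; on this read-out higher numbers stand for weaker inhibition and lower numbers for stronger inhibition:
- compound 1 `NCCCNc1c(C(=O)NCc2ccc(F)cc2)nc(Br)c2cccnc12`: 5000 nM
- compound 2 `Cc1ccc(S(=O)(=O)Oc2c(C(=O)NCc3ccc(F)cc3)nc(Br)c3cccnc23)cc1`: > 20000 nM

Compound 2 stands at > 20000 nM, which is a limit and not a number. The next structure is compound 3 `NCCCCCCNc1c(C(=O)NCc2ccc(F)cc2)nc(Br)c2cccnc12`, with (6-aminohexyl)amino in place of ((4-methylphenyl)sulfonyl)oxy on an aromatic carbon. The exchange lies on an aromatic carbon, ortho to a (4-fluorobenzyl)carbamoyl group and para to a bromo group. Within the data shown here, the one measured step bearing on it is an at least 4.0-fold higher number from compound 1 to compound 2 (0.60 log units; beyond the scatter), which runs the opposite way, with ((4-methylphenyl)sulfonyl)oxy replacing (3-aminopropyl)amino. It is beyond the scatter. Among the measured compounds shown here, no measured step covers the change from (3-aminopropyl)amino to (6-aminohexyl)amino, so the reversal is only a guide. A similar step towards stronger inhibition in this assay is expected, an at least 5.0-fold lower number from compound 2 to compound 3 (0.69 log units; beyond the scatter). For compound 3 the estimated value is 4000 nM, with an expected range of 1200 nM to 14000 nM.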

Compound 3, half-maximal inhibitory concentration: 6000 nM
The estimate for compound 3 lay 1.5-fold (0.18 log units) below the measured number; low and high end bracket the measured number.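

In this assay, (6-aminohexyl)amino in place of ((4-methylphenyl)sulfonyl)oxy on this aromatic carbon gives an at least 3.3-fold lower number from compound 2 to compound 3 (0.52 log units; beyond the scatter), so both aminoalkylamino groups shown now sit on the stronger side of the ((4-methylphenyl)sulfonyl)oxy group. Going from the (3-aminopropyl)amino chain to the (6-aminohexyl)amino chain gives a 1.2-fold higher number from compound 1 to compound 3 (0.08 log units; within the scatter), so across these two chains the added chain length brings no readable change at this position. Compound 2 stands at a limit of the assay and not at a number: the limit of > 20000 nM in this assay, at which 1 of the 3 values shown sits.

Open, going by these compounds, is whether a hexylamino chain without the terminal amine, or a chain ending in a hydroxyl group, would hold this level in this assay. Also open, on these data alone, is how a shorter 2-aminoethyl chain, or a cyclic amine such as piperazine, would read on this carbon.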